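Pyrrolidinylmethyl in place of piperidinylmethyl on the bromobenzoyl member

A few compounds are considered here, and "the series" means these few. Any claim that something is new, unique, unknown or untested is made for them only; others in the source may bear on it.

Measured so far:
compound 1 `COc1cc(OC)c(C(=O)c2ccccc2F)c(O)c1CN1CCCC1` — 15%
compound 2 `COc1cc(OC)c(C(=O)c2ccccc2Br)c(O)c1CN1CCCCC1` — 22%

Both compounds were tested in a functional assay on THP-1 cells (Homo sapiens) for inhibition, read by ELISA, with stated times of 30 min and 24 h, tested at 1 uM; a lower number here means a weaker effect, a higher number a stronger effect of the compound at the concentration tested. Compound 2 gives the larger of the two numbers shown, yet compound 1 sits within the usual scatter of it, so the two cannot be separated on these data. For the measured compounds named here, compound 1 and compound 2 differ from each other in two places at once, so no single step between them can be read, and only their two values are known.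

Compound 3 `COc1cc(OC)c(C(=O)c2ccccc2Br)c(O)c1CN1CCCC1` is not yet measured. Against compound 2 the difference is pyrrolidin-1-yl in place of piperidin-1-yl on a saturated chain carbon bound to an aromatic carbon. Compound 1 carries the same pyrrolidin-1-yl group on its saturated chain carbon bound to an aromatic carbon, and in this assay compound 1 gives 15%, a number within the scatter of compound 2.

Nothing shown separates the two ring sizes beyond the scatter, so no step beyond it is expected here. Compound 3 is therefore estimated to give 19%, with a range from 6% to 34%. The step this expectation implies is a number 3 percentage points lower from compound 2 to compound 3 (within the scatter).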

Compound 3, a percentage reported as activity, at one concentration (the size of the read-out at that concentration, not a potency): 19%
Compound 3: middle estimate and measured number agree at the digits printed; low and high end bracket the measured number.
By their numbers in this assay, from the lowest: compounds 1, 3 and 2 (each within the scatter of the next).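

In this assay, pyrrolidin-1-yl in place of piperidin-1-yl on a saturated chain carbon bound to an aromatic carbon can now be read as a single change, and it gives a number 3 percentage points lower from compound 2 to compound 3 (within the scatter) with the bromobenzoyl part held constant, so the two ring sizes are not separated at this position. For the compounds shown here, the same measurement also provides the first single-place reading of the halogen: bromo in place of fluoro on an aromatic carbon gives a number 4 percentage points higher from compound 1 to compound 3 (within the scatter) with the pyrrolidin-1-yl group held constant, and these two halogens are not separated either. No accompanying measurement bears on these results, so the steps stand without an explanation.

Going by these compounds alone, open is whether a different group on the same saturated chain carbon, such as morpholin-4-yl, dimethylamino or a carboxylic acid, would move the read-out beyond the usual scatter, since only two saturated rings with one nitrogen have been compared there. Also open, from the compounds shown here alone, is whether replacing the halogen on the aromatic carbon with methoxy or a nitrile would give a separable step on the shared core.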